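The source may report more compounds than this note shows. Statements on the series, on what has been measured and on what is new or still open speak of the compounds shown alone.

Compound 1 `Cc1ccccc1NC(=O)CCC(=O)OCCCCCCSc1ccc([N+](=O)[O-])c2nonc12` is the reference point here. In an ADME assay on HUVEC cells (Homo sapiens) for cytotoxicity, read by MTT assay, with a stated time of 72 h (a lower number here means a stronger inhibitor, a higher number a weaker inhibitor), compound 1 gives 1410 nM, the lowest of the three numbers measured. Compound 2 `O=C(CCC(=O)OCCCCCCSc1ccc([N+](=O)[O-])c2nonc12)Nc1ccc(Br)cc1` gives 1610 nM, and the step of a 1.1-fold higher number from compound 1 to compound 2 (0.06 log units; within the scatter) is within the scatter. Compound 3 `O=C(CCC(=O)OCCCCCCSc1ccc([N+](=O)[O-])c2nonc12)NCCN1CCCC1` gives 6070 nM, which makes it the furthest from compound 1: the step of a 4.3-fold higher number from compound 1 to compound 3 (0.63 log units; beyond the scatter) is modest but beyond the scatter, as is the step of a 3.8-fold higher number from compound 2 to compound 3 (0.58 log units; beyond the scatter).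

Compound 4 `O=C(CCC(=O)N1CCCCC1)OCCCCCCSc1ccc([N+](=O)[O-])c2nonc12` differs from compound 1 in one place: piperidin-1-yl in place of (2-methylphenyl)amino on a carbonyl carbon. Among the compounds with values here, the only steps that bear on this are the two in which a six-membered aromatic ring on the amide-type nitrogen was exchanged for a non-aromatic group, and both raised the number modestly. Compound 4 likewise gives up the aromatic ring and the hydrogen-bond donor, so a modest rise is expected, in the direction of a weaker inhibitor. The expected step is a 2.5-fold higher number from compound 1 to compound 4 (0.39 log units; beyond the scatter). For compound 4 the estimate in this assay is 3500 nM, with a range from 1500 nM to 8000 nM.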

Compound 4, half-maximal inhibitory concentration: 1990 nM
The estimate for compound 4 lay 1.8-fold (0.25 log units) above the measured number; measured number inside the range.
By their numbers in this assay, from the lowest: compounds 1, 2 and 4 (each within the scatter of the next); then compound 3.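

In this assay, the steps of a 1.4-fold higher number from compound 1 to compound 4 (0.15 log units; within the scatter) and a 1.2-fold higher number from compound 2 to compound 4 (0.09 log units; within the scatter) show that, on this carbonyl carbon, the aromatic ring and the amide hydrogen can both be replaced by piperidin-1-yl without a change beyond the scatter. The step of a 3.1-fold lower number from compound 3 to compound 4 (0.48 log units; beyond the scatter) sets compound 3 apart. Compound 3 and compound 4 both lack the aromatic ring. No measurement shown here explains these differences.

Still open, from the compounds shown here alone, is how a morpholin-4-yl ring or a small open-chain dimethylamino group would behave on this carbonyl carbon. Also open, going by these compounds, is whether a 2-(dimethylamino)ethyl group on the amide nitrogen would give a number closer to that of compound 3 or to those of the other three compounds.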